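Trading two chlorines for none on a five-membered ring

The compounds below may be only part of what the source reports. "The series", "measured", "known", "first", "only" and "open" are said of these compounds alone.

Compound 1 `O=C(Nc1cc2cc[nH]c(=O)c2cc1Cl)C1(c2ccccc2)CCNC1`: 240 nM
Compound 2 `O=C(Nc1cc2cc[nH]c(=O)c2cc1Cl)C1CNCC1c1ccc(Cl)cc1Cl`: 8 nM
Compound 3 `O=C(Nc1cc2cc[nH]c(=O)c2cc1Cl)C1CNCCC1c1ccccc1`: 6 nM

Of the compounds shown here, three sharing the same core have been measured in an assay on isolated protein for inhibition of Rho-associated protein kinase 2 (Homo sapiens), read by a luciferase reporter; a lower number here means a stronger inhibitor, a higher number a weaker inhibitor. Compound 1 gives 240 nM, compound 2 gives 8 nM and compound 3 gives 6 nM. Compound 2 stands second highest of the three numbers; its value and that of compound 3 lie within the scatter of each other, so no order between them can be claimed, while compound 1 sits far above both, beyond the scatter.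

The next compound, compound 4 `O=C(Nc1cc2cc[nH]c(=O)c2cc1Cl)C1CNCC1c1ccccc1`, differs from compound 2 in one place: phenyl in place of 2,4-dichlorophenyl on a saturated ring carbon. Among the compounds with values here, no measured pair in this set isolates that change, so the expectation rests on the neighbouring compounds alone. Compound 3 shows that a plain phenyl on a saturated ring carbon can sit at 6 nM, but compound 2 carries the two chlorines and the five-membered ring together.

In this assay compound 4 is expected to give a modestly higher number than compound 2, a step of a 3.1-fold higher number from compound 2 to compound 4 (0.49 log units; beyond the scatter), beyond the scatter but small. The estimate for compound 4 is 25 nM, with a range from 8 nM to 80 nM.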

Compound 4, half-maximal inhibitory concentration: 6 nM
Compound 4: middle estimate off by 4.2-fold (0.62 log units), on the high side; measured number outside the range, below it.
By their numbers in this assay, from the lowest: compounds 3, 4 and 2 (each within the scatter of the next); then compound 1.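

In this assay the exchange of 2,4-dichlorophenyl for phenyl on this saturated ring carbon gives a 1.3-fold lower number from compound 2 to compound 4 (0.12 log units; within the scatter) and shows that the two chlorines are not required for a number of this size. Within the data shown here, compound 2 alone carried the chlorines on the five-membered ring, so the earlier compounds could not separate their contribution; this pair shows that plain phenyl at this position stays within the scatter of the dichlorinated group. Nothing available accounts for this result.

On these data alone, whether a single chlorine on the phenyl would give the same picture remains open. So does the outcome of a methoxy group, a nitrile or an amine on that phenyl, or of a longer chain in its place on the same ring carbon.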